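Swapping Piperidinyl for Butylamino on a Shared Core

A few compounds are considered here, and "the series" means these few. Any claim that something is new, unique, unknown or untested is made for them only; others in the source may bear on it.

Measured compounds in a functional assay on OVCAR-3 cells (Homo sapiens) for cytotoxicity, read by MTT assay, with a stated time of 72 h; on this read-out lower numbers stand for stronger inhibition and higher numbers for weaker inhibition:
compound 1 `CN(C)c1nc2c(ncn2-c2ccccc2)c(=O)n1-c1ccccc1` — > 100000 nM
compound 2 `O=c1c2ncn(-c3ccccc3)c2nc(N2CCCCC2)n1-c1ccc(Cl)cc1` — > 100000 nM
compound 3 `CNc1nc2c(ncn2-c2ccccc2)c(=O)n1-c1ccccc1` — > 100000 nM

Each of these three values is a limit of the assay, not a measured number. Compound 1 sits at > 100000 nM, a limit. Compound 2 sits at > 100000 nM, also a limit. Compound 3 sits at > 100000 nM, again a limit. Among the compounds with values here, the only measured step, a step that the two limits leave unreadable from compound 1 to compound 3, is therefore unreadable. Compound 2 thus stands at the limit of > 100000 nM in this assay, at which 3 of the 3 values shown sit.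

Compound 4 `CCCCNc1nc2c(ncn2-c2ccccc2)c(=O)n1-c1ccc(Cl)cc1` differs from compound 2 by butylamino in place of piperidin-1-yl on an aromatic carbon. No readable step bears on this change. The expected step in this assay is a step that the limit leaves unreadable from compound 2 to compound 4, none beyond the scatter. Compound 4 is estimated at 150000 nM, within 50000 nM to 500000 nM, most likely reported only as a limit.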

Compound 4, half-maximal inhibitory concentration: 94800 nM
Beside the measured number, compound 4's estimate is 1.6-fold (0.20 log units) above it, within the range that was stated.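

In this assay, within the data shown here, compound 4 gives the only real number so far, on an aromatic carbon where the earlier compounds show only limits. Butylamino in place of piperidin-1-yl is an at least 1.0-fold lower number from compound 2 to compound 4 (0.02 log units; that floor lies within the scatter), so this change cannot yet be told apart from no change. Compound 2 holds a limit of the assay, not a number: the limit of > 100000 nM in this assay, at which 3 of the 4 values shown sit.

The compounds shown leave open whether a longer chain such as hexylamino, or a morpholin-4-yl ring, on this same carbon would give a clearly different number.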